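Ribonucleoside series: chain at the aromatic nitrogen and whole-animal response

This account rests on a few compounds, and the source may have more. Where it says the series, first, only, none or still open, it means among the compounds named here.

Measured compounds:
- compound 1 `CCn1c(=O)n(C2OC(CO)[C@@H](O)[C@H]2O)c2nc(N)nc(O)c21`: 82%
- compound 2 `NC(=O)Cn1c(=O)n(C2OC(CO)[C@@H](O)[C@H]2O)c2nc(N)nc(O)c21`: 72%
- compound 3 `CCCCCCCCCCn1c(=O)n(C2OC(CO)[C@@H](O)[C@H]2O)c2nc(N)nc(O)c21`: 0%

In a functional assay on the whole organism with Mus musculus as the target (on this read-out higher numbers stand for larger maximal responses and lower numbers for smaller maximal responses), compound 3 stands lowest of the three, and its gap to compound 2 and to compound 1 is beyond the scatter in both cases. Compound 4 `COc1ccc(Cn2c(=O)n(C3OC(CO)[C@@H](O)[C@H]3O)c3nc(N)nc(O)c32)cc1` differs from compound 3 in one place: 4-methoxyphenyl in place of nonyl on a saturated chain carbon bound to an aromatic nitrogen. For the measured compounds named here, two steps bear on it. a number 82 percentage points lower from compound 1 to compound 3 (beyond the scatter) and a number 72 percentage points lower from compound 2 to compound 3 (beyond the scatter) both accompany entry of the long chain that compound 4 no longer carries, whereas the small groups of compound 1 and compound 2 sit with the two higher numbers. Going by the values given here, a rise in this assay is therefore expected, of size a number 40 percentage points higher from compound 3 to compound 4 (beyond the scatter), though no measured compound carries an aromatic ring at this position and the size is uncertain. Compound 4 is estimated at 40%, within 5% to 80%.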

Compound 4, largest response reached (reported as maximal response), in percent of the reference or control that the assay uses: 14%
Beside the measured number, compound 4's estimate is 26 percentage points above it; low and high end bracket the measured number.
By their numbers in this assay, from the lowest: compound 3; then compound 4; then compounds 2 and 1 (each within the scatter of the next).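

In this assay, 4-methoxyphenyl in place of nonyl recovers only a modest part of the response (a number 14 percentage points higher from compound 3 to compound 4 (beyond the scatter)), so removing the long chain alone does not restore the higher numbers. The aromatic group remains far from the carbamoyl and methyl groups (a number 58 percentage points lower from compound 2 to compound 4 (beyond the scatter); a number 68 percentage points lower from compound 1 to compound 4 (beyond the scatter)), so at this position low numbers are not confined to the long chain. No supporting measurement accounts for these steps.

Still open, on these data alone, is how benzyl, butyl or an aminoethyl group on the aromatic nitrogen would read, and whether the methoxy group contributes at all.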